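Swapping Chloro for Fluoro in Compound 2

A few compounds are considered here, and "the series" means these few. Any claim that something is new, unique, unknown or untested is made for them only; others in the source may bear on it.

Of the compounds shown here, three built on one shared core have been measured in a functional assay on the whole organism (strain Wistar Albino) for inhibition, with Rattus norvegicus as the target, read by paw edema, with a stated time of 3 h, at a dose of 20 mg/kg; on this read-out higher numbers stand for more inhibition at the one dose given (going by the name of the read-out) and lower numbers for less inhibition. Compound 1 `COc1ccc(Cc2nnc3sc(-c4ccnc(Cl)c4)nn23)cc1OC` gives 22.5%. Compound 2 `Cc1occc1-c1nnc2sc(-c3ccnc(Cl)c3)nn12` gives 24.1%. Compound 3 `COc1ccc(Cl)c(-c2nnc3sc(-c4ccnc(F)c4)nn23)c1` gives 25.9%. On these numbers compound 2 stands second of the three, but its gap to its nearest neighbour, compound 1, and its gap to the furthest, compound 3, both fall within the usual scatter of repeated measurements, so the three values cannot really be told apart.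

Compound 4 `Cc1occc1-c1nnc2sc(-c3ccnc(F)c3)nn12` has not yet been measured. It differs from compound 2 in one place: fluoro in place of chloro on an aromatic carbon. Among the measured compounds shown here, no pair of measured compounds differs only in this way, so the effect of this swap in this assay has not been seen directly. Compound 3 carries the fluoro group but differs from compound 2 in other places as well, so its value alone says nothing about the swap.

With nothing to point either way, compound 4 is expected to move by no more than the scatter, an estimated step of a number 0.1 percentage points lower from compound 2 to compound 4 (within the scatter) that could fall in either direction. Compound 4 is accordingly estimated at 24%, with a range from 14% to 34%.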

Compound 4, a percentage reported as inhibition, in the whole organism at one dose (the size of the read-out at that dose, not a potency): 20.4%
For compound 4 the middle estimate is 3.6 percentage points above the measured one; measured number inside the range.
By their numbers in this assay, from the lowest: compounds 4, 1, 2 and 3 (each within the scatter of the next).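

In this assay, among the compounds shown here, the swap of 2-chloropyridin-4-yl for 2-fluoropyridin-4-yl, on the aromatic carbon next to the ring nitrogen, comes out as a number 3.7 percentage points lower from compound 2 to compound 4 (within the scatter) and gives the first direct reading of this change. At this position and on this background, the two halogens therefore cannot be told apart at the one dose tested, and a single pair cannot show a real effect of either direction. Nothing available bears on why the two numbers fall where they do.

On these data alone, what remains open is whether this position responds at all to a group other than a halogen, such as an amine, a methoxy group or a nitrile, in a way that would carry the read-out beyond the scatter. As far as these compounds go, it is also open whether the same swap would read alike with the dimethoxybenzyl group of compound 1 in place of the substituent shared by compound 2 and compound 4, and, as every number comes from one dose, how the two halogen compounds would compare across a range of doses.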